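The source may hold more compounds than are shown below. What is called first, only, known or untested is meant among the compounds shown, and "the series" means these compounds.

Notes on the series. The three measured compounds share one core and differ at two places. Compound 1 `CCO/N=C/Nc1cc(Cl)c(SSCC)c(Cl)c1` carries an (ethylsulfanyl)sulfanyl group on an aromatic carbon; in a physicochemical assay for lipophilicity, measured as octanol-water partition (on this read-out higher numbers stand for higher lipophilicity and lower numbers for lower lipophilicity), compound 1 gives 5. Compound 2 `CCO/N=C/Nc1cc(Cl)c(O)c(Cl)c1` has hydroxy in place of that group, and in this assay compound 2 gives 2.8; the step of a number 2.20 log units lower from compound 1 to compound 2 (beyond the scatter) is the only one measured. Compound 3 `C#CCc1c(Cl)cc(N/C=N/OC(C)C)cc1Cl` gives 3.9 in this assay and stands second highest of the three numbers, nearer to compound 1 than to compound 2, with both gaps beyond the scatter.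

Compound 4 `C#CCc1c(Cl)cc(N/C=N/Oc2ccccc2)cc1Cl` differs from compound 3 in one place: phenyl in place of isopropyl on an oxygen. Going by the values given here, no measured step touches the oxygen that bears this group; the step from compound 1 to compound 2 concerns a different position and a different kind of exchange, so it does not bear on the change here. The expectation rests only on the counted difference, a group of six carbon atoms in one aromatic ring entering for one of three carbon atoms, for which a rise in this assay is expected. The step from compound 3 to compound 4 is therefore estimated at a number 0.70 log units higher from compound 3 to compound 4 (beyond the scatter), beyond the scatter. Compound 4 is expected to give about 4.6 in this assay, with a range from 4.1 to 5.1.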

Compound 4, partition coefficient: 4.4
Beside the measured number, compound 4's estimate is 0.20 log units above it, within the range that was stated.
By their numbers in this assay, from the lowest: compound 2; then compound 3; then compound 4; then compound 1.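

At the oxygen whose other neighbour is the double-bonded nitrogen, phenyl in place of isopropyl gives in this assay a modest step, a number 0.50 log units higher from compound 3 to compound 4 (beyond the scatter), so this position responds measurably to this exchange. Going by these compounds alone, the earlier step, a number 2.20 log units lower from compound 1 to compound 2 (beyond the scatter), concerned a different position and a different kind of exchange, so this is the first direct reading at this oxygen. Nothing available gives a measured basis for the size or direction of this step.

A single exchange cannot separate the effect of the aromatic ring from that of the larger carbon count, since phenyl differs from isopropyl in both; a cyclohexyl group or a longer chain such as hexyl on the same oxygen would help to tell the two apart. As far as these compounds go, it also remains open whether the same exchange would give a similar step on the core of compound 1 or compound 2, which carry ethyl on this oxygen, and how a phenyl ring bearing an amine or a carboxylic acid would read in this assay.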